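A few compounds are considered here, and "the series" means these few. Any claim that something is new, unique, unknown or untested is made for them only; others in the source may bear on it.

Compound 1 `Cc1ccc(Oc2cc(C(=O)Nc3cnc(C)cn3)cc3oc(C)cc23)cc1`: 0.3 10^-6 cm/s
Compound 2 `Cc1cc2c(Oc3cnc(C(=O)N4CC(C)C4)cn3)cc(C(=O)Nc3cnccn3)cc2o1`: 14.9 10^-6 cm/s

In an ADME assay on MDCKII-LE cells (Canis lupus familiaris) for permeability (on this read-out lower numbers stand for lower permeability and higher numbers for higher permeability), compound 2 gives 14.9 10^-6 cm/s, the higher of the two numbers and beyond the scatter from compound 1, which gives 0.3 10^-6 cm/s. Compound 3 `COC1CN(C(=O)c2cnc(Oc3cc(C(=O)Nc4cnccn4)cc4oc(C)cc34)cn2)C1` keeps the frame of compound 2 and carries methoxy in place of methyl on a saturated ring carbon. Among the measured compounds shown here, no measured pair isolates this change, so the expectation rests on compound 2 alone, with its 14.9 10^-6 cm/s as the anchor. A small downward move, not beyond the scatter, is expected in this assay. The expected step is a 1.5-fold lower number from compound 2 to compound 3 (0.17 log units; within the scatter). The estimate for compound 3 is 10 10^-6 cm/s, with an expected range of 4 10^-6 cm/s to 20 10^-6 cm/s.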

Compound 3, apparent permeability: 21.8 10^-6 cm/s
Compound 3: the middle estimate sits 2.2-fold (0.34 log units) below what was measured, outside the stated range (above it).
By their numbers in this assay, from the lowest: compound 1; then compounds 2 and 3 (each within the scatter of the next).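

In this assay, among the compounds shown here, going from 3-methylazetidin-1-yl to 3-methoxyazetidin-1-yl gives a 1.5-fold higher number from compound 2 to compound 3 (0.17 log units; within the scatter) and is the first reading of a single change at this position. On this saturated ring carbon, two ring bonds from the ring nitrogen, the added oxygen and its hydrogen-bond acceptor leave the read-out of the pair inseparable within the scatter. No measurement shown bears on why the two compounds read this way.

Still open, going by these compounds, is how an amine, a carboxylic acid or a longer alkoxy chain on this ring carbon would read in this assay on the same frame. This single pair also leaves open whether methoxy in place of methyl would read the same on any other frame of the series.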